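This account rests on a few compounds, and the source may have more. Where it says the series, first, only, none or still open, it means among the compounds named here.

Compound 1 `COc1cc(C2=NN(C(C)=O)C(c3c(Cl)cccc3Cl)O2)cc(OC)c1OC` was tested in a functional assay on PC-3 cells (Homo sapiens) for antiproliferative activity, read by MTT assay, tested at 1 uM (a lower number here means a weaker effect, a higher number a stronger effect of the compound at the concentration tested), and gives 5.1%, the lower of the two values recorded so far. Compound 2 `COc1cc(C(=O)N/N=C/c2ccccc2F)cc(OC)c1OC` is built quite differently and in this assay gives 70.6%, a gap far beyond the scatter. Compound 3 `COc1cc(C2=NN(C(C)=O)C(c3cccc(C(F)(F)F)c3)O2)cc(OC)c1OC` has not yet been measured; it differs from compound 1 in one place: 3-(trifluoromethyl)phenyl in place of 2,6-dichlorophenyl on a saturated ring carbon. Going by the values given here, with no measured step of this kind to lean on, the expected step of a number 8.9 percentage points higher from compound 1 to compound 3 (within the scatter) is small and not beyond the scatter. Compound 3 is therefore expected to give roughly 14%, within a range from 0% to 45%.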

Compound 3, a percentage reported as inhibition, at one concentration (the size of the read-out at that concentration, not a potency): 30.1%
Beside the measured number, compound 3's estimate is 16.1 percentage points below it; measured number inside the range.
By their numbers in this assay, from the lowest: compound 1; then compound 3; then compound 2.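

Changing the aryl group on the saturated ring carbon matters: in this assay, 3-(trifluoromethyl)phenyl in place of 2,6-dichlorophenyl gives a number 25 percentage points higher from compound 1 to compound 3 (beyond the scatter). This position therefore responds to what it carries, even when both groups hold one six-membered aromatic ring of carbon only. Nothing measured here explains this step.

The compounds shown cannot separate the loss of the two chlorine atoms from the gain of the trifluoromethyl group. On these data alone, what an unsubstituted phenyl, or a phenyl bearing an amine or a carboxylic acid, would give at this position stays open.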